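From Ethyl to Phenylpiperazine on a Glycine Amide Chain

This account rests on a few compounds, and the source may have more. Where it says the series, first, only, none or still open, it means among the compounds named here.

Measured so far:
compound 1, `CCCC(=O)NCC(=O)N(C)c1ccc(Cl)cc1C(=O)c1ccccc1Cl`, in a functional assay on the whole organism for antagonist activity, with Mus musculus as the target; a lower number here means that less compound is needed, a higher number that more compound is needed for the effect: 0.98 mg/kg
compound 2, `CC(=O)NCC(=O)Nc1ccc(Cl)cc1C(=O)c1ccccc1Cl`: > 100 mg/kg
compound 3, `NCC(=O)NCC(=O)Nc1ccc([N+](=O)[O-])cc1C(=O)c1ccccc1Cl`: 2.64 mg/kg

Of the compounds shown here, three sharing one core have been tested in this assay. Compound 1 gives 0.98 mg/kg, the lowest of the two numbers shown. Compound 3 gives 2.64 mg/kg, a higher number whose gap to compound 1 lies beyond the scatter. For compound 2 the result is not a number but a limit, > 100 mg/kg; compound 2 thus sits at the limit of > 100 mg/kg in this assay, at which 1 of the 3 values shown sits.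

The compound that has not yet been measured is compound 4, `CN(C(=O)CNC(=O)CN1CCN(c2ccccc2)CC1)c1ccc(Cl)cc1C(=O)c1ccccc1Cl`. It differs from compound 1 in a single place: 4-phenylpiperazin-1-yl in place of ethyl on a saturated chain carbon bound to a carbonyl carbon. Among the compounds with values here, no pair of measured compounds differs in this way, so no measured step tells how large a change of this kind is in this assay. Given the size of the group that enters, a step beyond the scatter in either direction is plausible, but nothing among the measured compounds points to one direction over the other. Compound 4 is therefore expected to land near compound 1, with an estimate of 1.5 mg/kg and a range from 0.4 mg/kg to 6 mg/kg. This estimate means a step of a 1.5-fold higher number from compound 1 to compound 4 (0.18 log units; within the scatter).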

Compound 4, dose for half-maximal effect: 75 mg/kg
Estimate against measurement, compound 4: 50-fold (1.70 log units) below; measured number outside the range, above it.
By their numbers in this assay, from the lowest: compound 1; then compound 3; then compound 4. At a limit, above all of these: compound 2.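

Within the data shown here, replacing ethyl with 4-phenylpiperazin-1-yl on a saturated chain carbon bound to a carbonyl carbon gives a 77-fold higher number from compound 1 to compound 4 (1.88 log units; beyond the scatter) in this assay and is the first measured change at this position. The earlier compounds shown here offered no such pair, so they could not show how much this place on the glycine amide chain matters for the dose needed. This single step shows that the position is far from indifferent, since the whole-organism effect now takes much more compound even though the rest of compound 1 stays the same, but it describes only this one replacement.

The compounds shown leave open which part of the new group carries the change: the phenyl ring, the piperazine ring or simply the longer reach of the substituent, questions that a plain dimethylamino group, an unsubstituted piperazine or a longer straight alkyl chain such as hexyl at the same place could help to separate. Nothing measured here gives a reason for the size of this step.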